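Shortening the Selenium Side Group on a Shared Core

This account rests on a few compounds, and the source may have more. Where it says the series, first, only, none or still open, it means among the compounds named here.

In a functional assay on HepG2 cells (Homo sapiens) for inhibition, read by MTT assay, with a stated time of 48 h (a higher number here means a weaker inhibitor, a lower number a stronger inhibitor), compound 1 `COc1ccc(N(C)c2nc(C)nc3ccccc23)cc1C(=O)OCC[Se]C#N` gives 890 nM and compound 2 `COc1ccc(N(C)c2nc(C)nc3ccccc23)cc1C(=O)NCC[Se]C#N` gives 179 nM, the lower number of the two. Among the compounds with values here, the one measured step, a 5.0-fold lower number from compound 1 to compound 2 (0.70 log units; beyond the scatter), is modest and left the chain in place. Compound 3 `COc1ccc(N(C)c2nc(C)nc3ccccc23)cc1[Se]C` replaces that whole chain: a group of 2 heavy atoms (1 carbon, 1 selenium; no ring) in place of a group of 8 heavy atoms (4 carbon, 2 nitrogen, 1 oxygen, 1 selenium; no ring), on an aromatic carbon. Within the data shown here, no measured step covers so large a change, so the data fix no direction, and a move of similar or greater size either way is possible. The estimated change is a 1.2-fold lower number from compound 2 to compound 3 (0.08 log units; within the scatter), with wide uncertainty. For compound 3, the expected value is 150 nM, with an estimated range from 15 nM to 1200 nM.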

Compound 3, half-maximal inhibitory concentration: 17 nM
Beside the measured number, compound 3's estimate is 8.8-fold (0.95 log units) above it, within the range that was stated.
By their numbers in this assay, from the lowest: compound 3; then compound 2; then compound 1.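

At this aromatic carbon, the long chain with its carbonyl and nitrile is not needed for a low number in this assay: the small group of carbon and selenium gives an 11-fold lower number from compound 2 to compound 3 (1.02 log units; beyond the scatter), and a 52-fold lower number from compound 1 to compound 3 (1.72 log units; beyond the scatter). Both steps are large, whereas swapping the ester for the amide within the chain was only modest. No measurement here explains these drops. Because the whole chain changes at once, the part responsible stays unresolved. From the compounds shown here alone, it also remains open how a methylthio group or a longer alkyl chain on selenium would compare.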